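This account rests on a few compounds, and the source may have more. Where it says the series, first, only, none or still open, it means among the compounds named here.

Compound 1 `CC(C)(C)c1ccc(/C(=C/C(=O)Nc2ccc3c(c2)OCCO3)Cc2ccccc2)cc1` gives 110 nM in a functional assay on CHO cells for inhibition of transient receptor potential cation channel subfamily V member 1 (Homo sapiens); a lower number here means a stronger inhibitor, a higher number a weaker inhibitor.
Compound 2 `CC(C)c1ccc(/C=C/C(=O)Nc2ccc3c(c2)OCCO3)cc1` gives 82 nM in this assay.

Within the data shown here, of the two numbers known in this assay, the value of compound 2 lies within the scatter of that of compound 1, so the two stand together. Compound 3 `O=C(/C=C/c1ccc(C(F)(F)F)cc1)Nc1ccc2c(c1)OCCO2` carries trifluoromethyl in place of isopropyl on an aromatic carbon. Among the measured compounds shown here, no step between measured compounds bears on this change, so no direction is known. The expectation is a step of a 1.2-fold higher number from compound 2 to compound 3 (0.09 log units; within the scatter), no larger than the scatter. Compound 3 is therefore estimated at 100 nM in this assay, in the range 30 nM to 330 nM.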

Compound 3, half-maximal inhibitory concentration: 100 nM
Estimate against measurement, compound 3: no gap at the digits printed; low and high end bracket the measured number.
By their numbers in this assay, from the lowest: compounds 2, 3 and 1 (each within the scatter of the next).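

In this assay, trifluoromethyl in place of isopropyl on an aromatic carbon, para to a large group, gives a 1.2-fold higher number from compound 2 to compound 3 (0.09 log units; within the scatter). Among these compounds, this is the first step between compounds that differ in one place, and it shows that this exchange of groups leaves the number within the scatter. No independent evidence bears on this result, and the reason for it stays unknown.

The compounds shown leave open how an amine, a carboxylic acid or a nitrile would fare at this position. They also leave open whether the same exchange would give a similar step on another core.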